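The compounds below may be only part of what the source reports. "The series", "measured", "known", "first", "only" and "open" are said of these compounds alone.

Measured in a functional assay on MKN-45 cells (Homo sapiens) for antiproliferative activity, with a stated time of 72 h; on this read-out lower numbers stand for stronger inhibition and higher numbers for weaker inhibition:
- compound 1 `COc1cc(C(=O)c2cccc3ncccc23)cc(OC)c1OC`: 1200 nM
- compound 2 `COc1cc(C(=O)c2ccc3ncccc3c2)cc(OC)c1OC`: 16.3 nM
- compound 3 `COc1cc(C(=O)c2ccc3cccnc3c2)cc(OC)c1OC`: > 10000 nM

Compound 3 gives only a limit of the assay, > 10000 nM. Compound 2 holds the lower of the two actual numbers at 16.3 nM. Compound 1 gives 1200 nM, and the gap between these two numbers lies beyond the scatter.

Compound 4 `COc1ccc2cc(C(=O)c3cc(OC)c(OC)c(OC)c3)ccc2n1` has not yet been measured. It differs from compound 2 by methoxy in place of hydrogen on an aromatic carbon, next to the ring nitrogen: methoxy in place of hydrogen on an aromatic carbon.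

Going by the values given here, no measured pair isolates this change, so its size in this assay is uncertain. The gap between compound 1 at 1200 nM and compound 2 at 16.3 nM shows that values in this small set can differ widely, which argues for a broad range. The expected change is a moderate move toward weaker inhibition, with an estimated 3.7-fold higher number from compound 2 to compound 4 (0.57 log units; beyond the scatter). For compound 4 the estimated value is 60 nM, with an expected range of 10 nM to 500 nM.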

Compound 4, half-maximal inhibitory concentration: 139 nM
For compound 4 the middle estimate is 2.3-fold (0.36 log units) below the measured one, and the stated range covers the measured number.
By their numbers in this assay, from the lowest: compound 2; then compound 4; then compound 1. At a limit, above all of these: compound 3.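

In this assay the series now holds one pair that differs in one place, and it reads an 8.5-fold higher number from compound 2 to compound 4 (0.93 log units; beyond the scatter) for methoxy in place of hydrogen on an aromatic carbon, next to the ring nitrogen. This position therefore accepts methoxy with weaker inhibition, yet compound 4 still gives a real number, 139 nM, rather than a limit of the assay. Nothing in the data shown bears on why the step has this size.

Only this one replacement at this position is shown, so it remains open whether an amine, a hydroxyl or a longer chain such as ethoxy on the same carbon would give a smaller or larger step. From the compounds shown here alone, it also remains open whether methoxy would have a similar effect on the core of compound 1.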